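The compounds below may be only part of what the source reports. "The series", "measured", "known", "first", "only" and "open" are said of these compounds alone.

Working notes on the series. In a functional assay on KB cells (Homo sapiens) for inhibition, read by sulforhodamine B assay (a higher number here means a weaker inhibitor of growth, a lower number a stronger inhibitor of growth), compound 1 `CN(C)c1ccc(-c2ccc(-c3ccc(-c4nc5ccccc5[nH]4)cc3)cc2)cc1` gives 39300 nM and compound 2 `Clc1cccc(-c2ccc(-c3ccc(-c4nc5ccccc5[nH]4)cc3)cc2)c1` gives 32300 nM as its reading. These two values lie within the scatter of each other, so compound 2 holds no rank over compound 1, and both sit at the same weak level.

The next compound is compound 3 `COc1ccc(-c2ccc(-c3ccc(-c4nc5ccccc5[nH]4)cc3)cc2)cc1OC` and the change is 3,4-dimethoxyphenyl in place of 3-chlorophenyl on an aromatic carbon in the terminal group: 3,4-dimethoxyphenyl in place of 3-chlorophenyl on an aromatic carbon, para to a large group.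

Within the data shown here, the only measured guide is the earlier exchange at this same place, a 1.2-fold lower number from compound 1 to compound 2 (0.09 log units; within the scatter) and nothing more. Among the measured compounds shown here, it is a single step, and no compound with a methoxy group has been measured yet, so the support is thin. No shift beyond the scatter is expected in this assay for this exchange. The expected step is a 1.1-fold higher number from compound 2 to compound 3 (0.03 log units; within the scatter) and that estimate stays within the scatter. Compound 3 is expected at 35000 nM within an estimated range of 14000 nM to 75000 nM as a working figure.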

Compound 3, concentration for 50% growth inhibition: 9250 nM
Estimate against measurement, compound 3: 3.8-fold (0.58 log units) above, outside the stated range (below it).
By their numbers in this assay, from the lowest: compound 3; then compounds 2 and 1 (each within the scatter of the next).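

In this assay the terminal group at this position does move the reading, which the step between the two earlier compounds did not show: there is a 3.5-fold lower number from compound 2 to compound 3 (0.54 log units; beyond the scatter) and a 4.2-fold lower number from compound 1 to compound 3 (0.63 log units; beyond the scatter), both modest but beyond the scatter, and compound 3 therefore stands as the strongest inhibitor of growth of the three. The position is thus not indifferent to the group it carries, although the exchange changes more than one thing at once: 3,4-dimethoxyphenyl has 10 heavy atoms and 2 hydrogen-bond acceptors, against 7 heavy atoms and 0 hydrogen-bond acceptors for 3-chlorophenyl, and the numbers cannot separate these differences. No supporting measurement bears on why the number falls with this change.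

The compounds shown leave open whether both methoxy groups are needed for the lower number, since a phenyl group carrying a single methoxy group would be required to tell one from two. They also leave open whether other oxygen-bearing groups, such as a hydroxy group or a carboxylic acid, or a longer ether chain in place of methoxy, would match or pass compound 3 in this position.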